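The source may report more compounds than this note shows. Statements on the series, on what has been measured and on what is new or still open speak of the compounds shown alone.

Measured so far in a functional assay on SGC-7901 cells (Homo sapiens) for antiproliferative activity, read by MTT assay, with a stated time of 24 h; on this read-out higher numbers stand for weaker inhibition and lower numbers for stronger inhibition:
Compound 1 `O=C(NNc1ccccc1F)c1cccc(NS(=O)(=O)c2cnc(O)nc2O)c1` gives > 20000 nM
Compound 2 `Cc1ccccc1C(=O)NNC(=O)c1cccc(NS(=O)(=O)c2cnc(O)nc2O)c1` gives > 20000 nM

Compound 2 gives > 20000 nM as a limit of the assay and not as a number. Compound 1 gives > 20000 nM as a limit too. Neither compound therefore has a measured potency in this assay, and the evidence so far is the limit of > 20000 nM in this assay, at which 2 of the 2 values shown sit, and nothing more.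

Compound 3 `O=C(NNC(=O)c1ccccc1F)c1cccc(NS(=O)(=O)c2cnc(O)nc2O)c1` differs from compound 2 by fluoro in place of methyl on an aromatic carbon on an aromatic carbon, ortho to a large group, so that (2-methylphenyl)carbonyl becomes (2-fluorophenyl)carbonyl.

Within the data shown here, the only measured step is a step that the two limits leave unreadable from compound 1 to compound 2 and it offers no size to carry over to this change. Among the measured compounds shown here, no step of any readable size is therefore expected in this assay, and no direction can be argued from the data. With compound 2 at > 20000 nM as a limit, compound 3 is expected to end at a limit as well. The expected change is a step that the limit leaves unreadable from compound 2 to compound 3 and is none beyond the scatter. For compound 3 the estimated value is 25000 nM with an expected range from 10000 nM to 60000 nM if a number is reported at all.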

Compound 3, half-maximal inhibitory concentration: > 20000 nM
Compound 3 gave a limit, no number; the forecaster's own chance of this, stated with the estimate: 80%; the middle value is on the limit's open side.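

In this assay compound 3 gives > 20000 nM, which is a limit and not a number. No step between compound 1, compound 2 and compound 3 can be read: the limit of > 20000 nM in this assay, at which 3 of the 3 values shown sit.

The compounds shown leave open whether any of the 2-fluorophenyl, (2-methylphenyl)carbonyl or (2-fluorophenyl)carbonyl groups on the shared core gives a measurable potency in this assay, and how these groups would rank.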